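Replacing 4-nitrophenyl with pyridin-4-yl on the shared core

A few compounds are considered here, and "the series" means these few. Any claim that something is new, unique, unknown or untested is made for them only; others in the source may bear on it.

In a functional assay on HeLa cells (Homo sapiens) for cytotoxicity, read by WST assay, with a stated time of 48 h (a lower number here means a stronger inhibitor, a higher number a weaker inhibitor), compound 1 (`C=CC[C@H]1C[C@@H]([C@@H](O)c2ccccc2)CO[C@@H]1c1ccccc1`) gives 25400 nM, compound 2 (`Oc1cccc(/C=C/C[C@H]2C[C@@H]([C@@H](O)c3ccccc3)CO[C@@H]2c2ccccc2)c1`) gives 18600 nM and compound 3 (`O=[N+]([O-])c1ccc(/C=C/C[C@H]2C[C@@H]([C@@H](O)c3ccccc3)CO[C@@H]2c2ccccc2)cc1`) gives 12400 nM. Compound 3 has a lower number than compound 1, beyond the scatter, but lies within the scatter of compound 2. Compound 4 (`O[C@@H](c1ccccc1)[C@H]1CO[C@H](c2ccccc2)[C@@H](C/C=C/c2ccncc2)C1`) follows from pyridin-4-yl in place of 4-nitrophenyl on a double-bonded chain carbon bound to a double-bonded chain carbon, with pyridin-4-yl in place of 4-nitrophenyl on a double-bonded chain carbon bound to a double-bonded chain carbon. For the measured compounds named here, two measured steps bear on this: a 1.4-fold lower number from compound 1 to compound 2 (0.14 log units; within the scatter) and a 1.5-fold lower number from compound 2 to compound 3 (0.18 log units; within the scatter). The second changes the same place, and both stay within the scatter. No step beyond the scatter is therefore expected in this assay. The estimated step is a 1.3-fold higher number from compound 3 to compound 4 (0.11 log units; within the scatter). Compound 4 is estimated at 16000 nM, with an expected range of 7000 nM to 34000 nM.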

Compound 4, half-maximal inhibitory concentration: > 100000 nM
Compound 4: only a limit was reported (the forecaster's own chance of this, stated with the estimate: 5%); middle value at least 6.2-fold (0.79 log units) away from the limit.
By their numbers in this assay, from the lowest: compounds 3, 2 and 1 (each within the scatter of the next, the first and the last beyond it). At a limit, above all of these: compound 4.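

In this assay this place, on a double-bonded chain carbon bound to a double-bonded chain carbon, turns out to be sensitive to the group it carries: pyridin-4-yl gives an at least 8.0-fold higher number from compound 3 to compound 4 (0.90 log units; beyond the scatter) and an at least 5.3-fold higher number from compound 2 to compound 4 (0.73 log units; beyond the scatter), although 3-hydroxyphenyl and 4-nitrophenyl lay within the scatter of each other. The step from vinyl runs the same way, an at least 3.9-fold higher number from compound 1 to compound 4 (0.59 log units; beyond the scatter), whereas the 3-hydroxyphenyl of compound 2 stayed within the scatter of compound 1. The value of compound 4 is only a limit: the limit of > 100000 nM in this assay, at which 1 of the 4 values shown sits.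

From the compounds shown here alone, the true size of these steps stays open, and so does whether pyridin-3-yl, 4-aminophenyl or 4-carboxyphenyl in this place would follow pyridin-4-yl or 4-nitrophenyl.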